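Second fluoro on the azepanyl-bearing ring of the indazole series

The compounds below may be only part of what the source reports. "The series", "measured", "known", "first", "only" and "open" are said of these compounds alone.

Compound 1, `O=C(NCc1ccc(N2CCCCCC2)cc1)Nc1cccc2cnccc12`, is the parent of the set. In a functional assay for antagonist activity at transient receptor potential cation channel subfamily V member 1 (Homo sapiens), read by calcium flux (on this read-out lower numbers stand for stronger inhibition and higher numbers for weaker inhibition), compound 1 gives 3.3 nM. Compound 2, `O=C(NCc1ccc(N2CCCCCC2)c(F)c1)Nc1cccc2cnccc12`, carries the change (fluoro in place of hydrogen on an aromatic carbon); compound 2 gives 2.8 nM in this assay, so the step of a 1.2-fold lower number from compound 1 to compound 2 (0.07 log units; within the scatter) is small. Compound 3, `O=C(NCc1ccc(N2CCCCCC2)c(F)c1)Nc1cccc2[nH]ncc12`, has a different core; the difference between the two cores is not broken down here. Compound 3 gives 14.2 nM in this assay, the highest of the three numbers.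

Compound 4, `O=C(NCc1cc(F)c(N2CCCCCC2)c(F)c1)Nc1cccc2[nH]ncc12`, is not yet measured. It differs from compound 3 by fluoro in place of hydrogen on an aromatic carbon. This is the same kind of change as from compound 1 to compound 2, but the place is not the same word for word: in compound 4 the entering fluoro sits meta to a fluoro group as well as ortho to the azepan-1-yl group and meta to a large group, whereas in compound 2 no fluoro group is already present on that ring.

Among the measured compounds shown here, the only precedent for this kind of change is the step from compound 1 to compound 2, which stayed within the scatter, so for compound 4 a step of a 1.2-fold lower number from compound 3 to compound 4 (0.07 log units; within the scatter) in this assay is expected, resting on that earlier step. Compound 4 is therefore estimated at 12 nM, with a range from 5 nM to 30 nM in this assay.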

Compound 4, half-maximal inhibitory concentration: 39.3 nM
For compound 4 the middle estimate is 3.3-fold (0.52 log units) below the measured one; the whole stated range lies below it.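

In this assay, fluoro in place of hydrogen on an aromatic carbon does not carry over unchanged from one core to the other, giving a 2.8-fold higher number from compound 3 to compound 4 (0.44 log units; beyond the scatter). The two steps are set apart by more than scatter, so the small step on the core of compound 1 is not a safe guide on the core of compound 3: the same change on two cores in this assay, a 1.2-fold lower number (0.07 log units; within the scatter) from compound 1 to compound 2 and a 2.8-fold higher number (0.44 log units; beyond the scatter) from compound 3 to compound 4, 3.3-fold (0.51 log units) apart, beyond the scatter of two such steps. This does not show that the core alone sets the gap: the entering fluoro in compound 4 sits meta to a fluoro group, whereas compound 2 has no fluoro group already on that ring, so the core and the earlier fluoro vary together, and each case rests on a single pair.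

Still open, from the compounds shown here alone, is how the same step behaves on the core of compound 3 with no fluoro on that ring, and on the core of compound 1 with one already present. Also open, going by these compounds, is whether a chloro or methyl group at that place would follow fluoro.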